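Compound 3 to compound 4: furan-3-yl in place of phenyl

This account rests on a few compounds, and the source may have more. Where it says the series, first, only, none or still open, it means among the compounds named here.

Measured so far in a functional assay on A549 cells (Homo sapiens), read by sulforhodamine B assay, with a stated time of 5 days (a higher number here means a weaker inhibitor of growth, a lower number a stronger inhibitor of growth), as follows
compound 1 `OC[C@H]1O[C@@H](n2cc(F)c3c(-c4ccccc4)ncnc32)[C@H](O)[C@@H]1O` gives > 10000 nM as a limit and not a number
compound 2 `OC[C@H]1O[C@@H](n2cc(F)c3c(-c4cccs4)ncnc32)[C@H](O)[C@@H]1O` gives 61 nM as a number
compound 3 `OC[C@H]1O[C@@H](n2cc(Cl)c3c(-c4ccccc4)ncnc32)[C@H](O)[C@@H]1O` gives 2500 nM as a number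

Of the two exact numbers, compound 3 at 2500 nM is the higher, and the gap down to compound 2 at 61 nM lies beyond the scatter. Compound 4 `OC[C@H]1O[C@@H](n2cc(Cl)c3c(-c4ccoc4)ncnc32)[C@H](O)[C@@H]1O` keeps the chloro of compound 3 and differs at one place, furan-3-yl in place of phenyl on an aromatic carbon next to the ring nitrogen of the six-membered aromatic ring.

The nearest measured change is an at least 160-fold lower number from compound 1 to compound 2 (2.21 log units; beyond the scatter) for thiophen-2-yl in place of phenyl, a large step. On these data alone, it was seen only once, with fluoro rather than chloro, and furan-3-yl itself is untested. The other measured change, an at least 4.0-fold lower number from compound 1 to compound 3 (0.60 log units; beyond the scatter) for chloro in place of fluoro, is at least modest and does not touch the phenyl. On the precedent of an at least 160-fold lower number from compound 1 to compound 2 (2.21 log units; beyond the scatter) a large move to a lower number is expected, though the range must stay wide. The estimated step is a 50-fold lower number from compound 3 to compound 4 (1.70 log units; beyond the scatter) in this assay and lies beyond the scatter. The estimated value for compound 4 is 50 nM with a range of 10 nM to 400 nM expected.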

Compound 4, concentration for 50% growth inhibition: 1100 nM
The estimate for compound 4 lay 22-fold (1.34 log units) below the measured number; measured number above the stated range.
By their numbers in this assay, from the lowest: compound 2; then compound 4; then compound 3. At a limit, above all of these: compound 1.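

In this assay the exchange of phenyl for a five-membered aromatic ring now has exact numbers at both ends, giving a 2.3-fold lower number from compound 3 to compound 4 (0.36 log units; beyond the scatter) and showing that this position still responds with the chloro in place. The direction matches that of an at least 160-fold lower number from compound 1 to compound 2 (2.21 log units; beyond the scatter) but the furan-3-yl step is only modest, so a large step does not follow from every exchange of phenyl for a five-membered aromatic ring. The thiophen-2-yl step is only a bound, because compound 1 stands at a limit and not at an exact number: the limit of > 10000 nM in this assay, at which 1 of the 4 values shown sits.

Still open, on these data alone, is how thiophen-2-yl behaves with the chloro and how furan-3-yl behaves with the fluoro, so the effects of the ring and the halogen cannot yet be separated. Also open, as far as these compounds go, is whether a group of a different kind on this aromatic carbon, such as an amine or a short alkyl chain, would keep the growth inhibition seen with the five-membered aromatic rings.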